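This account rests on a few compounds, and the source may have more. Where it says the series, first, only, none or still open, it means among the compounds named here.

Compound 1 `FC(F)(F)c1ccc2nc(-c3cccc(-c4nc5ccc(C(F)(F)F)cc5[nH]4)c3)[nH]c2c1` and compound 2 `COc1cc(-c2nc3ccc(C(F)(F)F)cc3[nH]2)cc(-c2nc3ccc(C(F)(F)F)cc3[nH]2)c1` share one core and differ only in that compound 2 carries a methoxy group where compound 1 carries hydrogen on an aromatic carbon. In a functional assay on HeLa cells (Homo sapiens) for cytotoxicity, read by MTT assay, with a stated time of 48 h (a lower number here means a stronger inhibitor, a higher number a weaker inhibitor), compound 1 gives 8000 nM, and compound 2 gives 8400 nM. Of the two numbers compound 2 has the higher one, yet the gap a 1.1-fold higher number from compound 1 to compound 2 (0.02 log units; within the scatter) is within the scatter, so the two compounds cannot be told apart on this basis. Compound 3 `O=[N+]([O-])c1cc(-c2nc3ccc(C(F)(F)F)cc3[nH]2)cc(-c2nc3ccc(C(F)(F)F)cc3[nH]2)c1` has not yet been measured in this assay. It differs from compound 2 in one place: nitro in place of methoxy on an aromatic carbon. For the measured compounds named here, the only step that bears on this position is a 1.1-fold higher number from compound 1 to compound 2 (0.02 log units; within the scatter), which was within the scatter, and nothing else among the measured compounds speaks to a nitro group. No step beyond the scatter is therefore expected in this assay, though the range is kept wide. For compound 3 the estimate in this assay is 8500 nM, between 3000 nM and 25000 nM, an expected step of a 1.0-fold higher number from compound 2 to compound 3 (0.01 log units; within the scatter).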

Compound 3, half-maximal inhibitory concentration: 1900 nM
For compound 3 the middle estimate is 4.5-fold (0.65 log units) above the measured one, and the stated range ends above it.
By their numbers in this assay, from the lowest: compound 3; then compounds 1 and 2 (each within the scatter of the next).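

In this assay this position proves responsive to the group it carries: there is a 4.4-fold lower number from compound 2 to compound 3 (0.65 log units; beyond the scatter) and also a 4.2-fold lower number from compound 1 to compound 3 (0.62 log units; beyond the scatter) with both steps beyond the scatter. Methoxy in place of hydrogen had given only a 1.1-fold higher number from compound 1 to compound 2 (0.02 log units; within the scatter) and so had revealed no effect at this position, whereas nitro makes compound 3 the strongest inhibitor of the three. The data shown offer no explanation for this difference between the two groups.

On these data alone, with only hydrogen, methoxy and nitro represented, it remains open whether the lower number is particular to nitro or would also appear with a nitrile, an amine or a carboxylic acid at this position. As far as these compounds go, it is also open whether a longer chain in place of methoxy would leave the number within the scatter of compound 2.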